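A Chlorine Swap on the Sulfur-Linked Ring

This account rests on a few compounds, and the source may have more. Where it says the series, first, only, none or still open, it means among the compounds named here.

compound 1 `Nc1ccccc1NC(=O)c1ccc(CSc2cccc(F)c2)cc1` gives 76.3%
compound 2 `Nc1ccccc1NC(=O)/C=C/c1ccc(CSc2ccc(C(F)(F)F)cn2)cc1` gives 3.96%
compound 3 `Nc1ccccc1NC(=O)c1ccc(CSc2ccc(C(F)(F)F)cn2)cc1` gives 5.34%

These three values come from a functional assay on A-375 cells (Homo sapiens) for inhibition, read by CCK-8 assay, with a stated time of 72 h, tested at 8 uM (on this read-out higher numbers stand for more inhibition of growth at the one concentration tested and lower numbers for less inhibition of growth), and compound 1 stands highest, with both other compounds lower by far more than the usual scatter. Compounds 2 and 3 lie within the scatter of each other, and both carry a different group on the sulfur.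

Compound 4 `Nc1ccccc1NC(=O)c1ccc(CSc2ccc(Cl)cc2)cc1` keeps the core of compound 1 and changes one group, with 4-chlorophenyl in place of 3-fluorophenyl on a sulfur (the group that enters is again a six-membered aromatic ring of carbon only). Within the data shown here, no measured pair isolates this kind of change, so the expectation rests mainly on compound 1 at 76.3% as a starting point. A modest fall in this assay is expected, quite possibly within the scatter, and the estimated change is a number 11.3 percentage points lower from compound 1 to compound 4 (beyond the scatter) with wide uncertainty. For compound 4 the expected value is 65% with an estimated range from 35% to 88% as the likely span.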

Compound 4, percent growth inhibition at one concentration: 48.6%
Estimate against measurement, compound 4: 16.4 percentage points above; low and high end bracket the measured number.
By their numbers in this assay, from the lowest: compounds 2 and 3 (each within the scatter of the next); then compound 4; then compound 1.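

In this assay, among these compounds, putting 4-chlorophenyl in place of 3-fluorophenyl on the sulfur gives a number 27.7 percentage points lower from compound 1 to compound 4 (beyond the scatter), the first comparison here that changes only one place. The step shows that the number responds to this group even though a six-membered aromatic ring of carbon only stays on the sulfur, and compound 4 still gives 48.6%. This swap changes both the halogen and its place on the ring, and no measurement on hand explains the fall.

The compounds shown leave open how 3-chlorophenyl or 4-fluorophenyl on the same sulfur would read, and these two groups could separate the halogen from its place on the ring. Also open, as far as these compounds go, is what a methoxy group or an amine on this ring would do to the number.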